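Hydroxy for chloro on the anilino ring

The source may hold more compounds than are shown below. What is called first, only, known or untested is meant among the compounds shown, and "the series" means these compounds.

Measured compounds:
compound 1 `Clc1ccc(Nc2ccc(N3CC4CC(C3)N4)cn2)cc1`, 2.49 nM
compound 2 `Clc1ccc(Nc2cncc(N3CC4CC(C3)N4)c2)cc1`, 0.118 nM

In an assay on cell membranes for displacement of a labelled ligand from Neuronal acetylcholine receptor; alpha4/beta2 (Rattus norvegicus) (on this read-out lower numbers stand for stronger inhibition and higher numbers for weaker inhibition), compound 1 gives 2.49 nM, and compound 2 gives 0.118 nM. Compound 1 therefore holds the higher of the two numbers in this assay, and its gap to compound 2 lies beyond the scatter of repeated measurements. The two measured compounds differ in more than one place, so no single step can be read from them.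

Compound 3 `Oc1ccc(Nc2ccc(N3CC4CC(C3)N4)cn2)cc1` differs from compound 1 by hydroxy in place of chloro on an aromatic carbon. For the measured compounds named here, no measured pair carries this change, so its size has no precedent here. The expectation for this step is a modest rise in the number, a 2.4-fold higher number from compound 1 to compound 3 (0.38 log units; beyond the scatter), with an outcome within the scatter not excluded. Compound 3 is expected to give about 6 nM, with a range from 1.5 nM to 25 nM.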

Compound 3, inhibition constant: 7.1 nM
Compound 3: middle estimate off by 1.2-fold (0.07 log units), on the low side; low and high end bracket the measured number.
By their numbers in this assay, from the lowest: compound 2; then compound 1; then compound 3.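

Chloro to hydroxy at this place, on an aromatic carbon para to a large group, gives a 2.9-fold higher number from compound 1 to compound 3 (0.46 log units; beyond the scatter) in this assay and is the first single-place step in the series. It shows that chloro on the anilino ring can be replaced without a large loss, since compound 3 with hydroxy still reaches 7.1 nM and stays in the same range as compound 1 rather than falling away sharply. Nothing on hand accounts for the size of this step.

Open, as far as these compounds go, is whether the core of compound 2 at 0.118 nM would pay a similar price for the same change. From the compounds shown here alone, how an amine or a methoxy group at this place would compare with chloro and hydroxy also stays open.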